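Fluorophenyl sulfones in the piperidinyl series, next step

A few compounds are considered here, and "the series" means these few. Any claim that something is new, unique, unknown or untested is made for them only; others in the source may bear on it.

Of the compounds shown here, three of the shared core have been measured in an assay on HeLa cells for displacement of a labelled ligand from 5-hydroxytryptamine receptor 6 (Homo sapiens); on this read-out higher numbers stand for weaker inhibition and lower numbers for stronger inhibition. Compound 1 `CCN1CCC(n2cc(S(=O)(=O)c3cccc(F)c3)c3cccnc32)C1` carries a 3-fluorophenyl on the sulfonyl sulfur and an ethyl-substituted five-membered amine; in this assay compound 1 gives 8.3 nM. Compound 2 `O=S(=O)(c1ccccc1)c1cn(C2CCCNC2)c2ncccc12` has the unsubstituted phenyl and the six-membered amine and gives 4.9 nM. Compound 3 `O=S(=O)(c1ccccc1F)c1cn(C2CCCNC2)c2ncccc12` differs from compound 2 only by a fluorine, and compound 3 gives 2 nM, the lowest of the three numbers, with compound 2 nearest and compound 1 furthest.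

For the measured compounds named here, the one single-point step measured so far is a 2.5-fold lower number from compound 2 to compound 3 (0.39 log units; beyond the scatter), a modest gain on adding fluorine to the phenyl ring.

Compound 4 `O=S(=O)(c1cccc(F)c1)c1cn(C2CCCNC2)c2ncccc12` is not yet measured. It differs from compound 3 by 3-fluorophenyl in place of 2-fluorophenyl on a sulfonyl sulfur. Going by the values given here, no measured pair isolates this change: compound 1 also bears a 3-fluorophenyl but with a different amine, so its value against compound 3 mixes two changes. The step from compound 2 to compound 3 shows that a fluorine on this ring matters, while compound 1 suggests the 3-fluorophenyl pattern still sits in the same range. A small rise is expected, a 2.0-fold higher number from compound 3 to compound 4 (0.30 log units; within the scatter), within or just beyond the scatter. Compound 4 is therefore estimated at 4 nM, range 1.5 nM to 10 nM.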

Compound 4, inhibition constant: 2.4 nM
Beside the measured number, compound 4's estimate is 1.7-fold (0.22 log units) above it; low and high end bracket the measured number.
By their numbers in this assay, from the lowest: compounds 3 and 4 (each within the scatter of the next); then compounds 2 and 1 (each within the scatter of the next).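

In this assay, for the compounds shown here, 3-fluorophenyl in place of 2-fluorophenyl on a sulfonyl sulfur gives a 1.2-fold higher number from compound 3 to compound 4 (0.08 log units; within the scatter) and so makes no readable difference, which is the first direct read of this change with the amine held constant. The gain seen on adding fluorine therefore does not rest on the 2-fluorophenyl alone: alongside a 2.5-fold lower number from compound 2 to compound 3 (0.39 log units; beyond the scatter) there now stands a 2.0-fold lower number from compound 2 to compound 4 (0.31 log units; beyond the scatter) for the 3-fluorophenyl. Going by these compounds alone, the amine can also be read by itself for the first time, with a 3.5-fold lower number from compound 1 to compound 4 (0.54 log units; beyond the scatter) on changing to piperidin-3-yl from 1-ethylpyrrolidin-3-yl on an aromatic nitrogen while the 3-fluorophenyl stays in place.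

The compounds shown leave open whether a 4-fluorophenyl, a chlorophenyl or a methoxyphenyl on the sulfonyl sulfur would stay in the range of the two fluorophenyl compounds. The amine step also joins ring size and the ethyl group in one change, and a 1-ethylpiperidin-3-yl would be needed to pull these two apart.

No evidence at hand bears on these steps.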